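A second methyl on the chain carbon of compound 3

A few compounds are considered here, and "the series" means these few. Any claim that something is new, unique, unknown or untested is made for them only; others in the source may bear on it.

In a functional assay on the whole organism (arterial blood) with Rattus norvegicus as the target (a lower number here means that less compound is needed, a higher number that more compound is needed for the effect), compound 3 `Cc1nc2cnccc2n1CC1CCN(C(=O)CC(C)c2ccccc2)CC1` gives 0.033 mg/kg and lies within the scatter of compound 2 `COC(=O)NC(CC(=O)N1CCC(Cn2c(C)nc3cnccc32)CC1)c1ccccc1` at 0.035 mg/kg in the same test. Compound 1 `Cc1nc2cnccc2n1CC1CCN(C(=O)CNC(c2ccccc2)c2ccccc2)CC1` gives 0.067 mg/kg as a higher number, beyond the scatter from compound 3. Compound 4 `Cc1nc2cnccc2n1CC1CCN(C(=O)CC(C)(C)c2ccccc2)CC1` follows through one change methyl in place of hydrogen on a saturated chain carbon bound to an aromatic carbon and two saturated chain carbons with methyl in place of hydrogen on a saturated chain carbon bound to an aromatic carbon and two saturated chain carbons. Among the measured compounds shown here, the one measured step at this carbon is a 1.1-fold lower number from compound 2 to compound 3 (0.03 log units; within the scatter) and it stayed within the scatter, though no measured step adds a second methyl there. The expected step is a 1.2-fold higher number from compound 3 to compound 4 (0.08 log units; within the scatter) and no change beyond the scatter is expected. In this assay compound 4 is estimated at 0.04 mg/kg (expected range 0.015 mg/kg to 0.11 mg/kg).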

Compound 4, dose for 50% inhibition: 0.012 mg/kg
Compound 4: middle estimate off by 3.3-fold (0.52 log units), on the high side, and the stated range ends above it.
By their numbers in this assay, from the lowest: compound 4; then compounds 3, 2 and 1 (each within the scatter of the next, the first and the last beyond it).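

In this assay, the step of a 2.8-fold lower number from compound 3 to compound 4 (0.44 log units; beyond the scatter) shows that methyl in place of hydrogen on this saturated chain carbon can move the number beyond the scatter, which the earlier step at this carbon, a 1.1-fold lower number from compound 2 to compound 3 (0.03 log units; within the scatter), did not do. The lower number goes with 1-methyl-1-phenylethyl rather than 1-phenylethyl, though this is a single pair of compounds. Nothing measured here explains the step. The compounds shown leave open whether an ethyl or a hydroxyl group on this carbon would keep the lower number.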